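A few compounds are considered here, and "the series" means these few. Any claim that something is new, unique, unknown or untested is made for them only; others in the source may bear on it.

Measured compounds:
- compound 1: `CC1(C)CC(NC(=O)Nc2ccccc2Cl)c2cc(Cl)ccc2O1`, 20000 nM
- compound 2: `CC(=O)NC1CC(C)(C)Oc2ccc(Cl)cc21`, "not determined" (no result reported)
- compound 3: `CCNC(=O)NC1CC(C)(C)Oc2ccc(Cl)cc21`, "not determined" (no result reported)

The account concerns compound 3 and its relation to compound 4. Compound 3, `CCNC(=O)NC1CC(C)(C)Oc2ccc(Cl)cc21`, has no single number in a functional assay on T98G cells (Homo sapiens) for inhibition, read by MTT assay, with a stated time of 72 h; a higher number here means a weaker inhibitor, a lower number a stronger inhibitor: for compound 3 the entry reads "not determined" (no result reported). The same holds for compound 2, `CC(=O)NC1CC(C)(C)Oc2ccc(Cl)cc21`, for which the entry in this assay reads "not determined" (no result reported), so that compound 3 stands nowhere on the numbers shown. Among the measured compounds shown here, the only measured compound with a reported value is compound 1, `CC1(C)CC(NC(=O)Nc2ccccc2Cl)c2cc(Cl)ccc2O1`, which in this assay gives 20000 nM, a weak result.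

Compound 4, `CC1(C)CC(NC(=O)Nc2cccc(Cl)c2)c2cc(Cl)ccc2O1`, is obtained from compound 3 by a single change: 3-chlorophenyl in place of ethyl on an amide-type nitrogen. For the measured compounds named here, with no number for compound 3 and no step between measured compounds, the size and direction of this change in this assay cannot be read from data; any expectation must rest on compound 1 alone, which shares the urea and the core and differs from compound 4 only in the chlorophenyl group on that same nitrogen.

On that basis compound 4 is expected to be a weak inhibitor in this assay, estimated at 20000 nM with a range of 5000 nM to 60000 nM, because compound 1 gives 20000 nM and there is nothing to suggest a large departure from it.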

Compound 4, half-maximal inhibitory concentration: 25000 nM
Beside the measured number, compound 4's estimate is 1.3-fold (0.10 log units) below it; the range from low to high includes it.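

In this assay, putting 3-chlorophenyl in place of 2-chlorophenyl on the amide-type nitrogen gives a 1.3-fold higher number from compound 1 to compound 4 (0.10 log units; within the scatter), so this first pair of measured compounds shows no separation between the two chlorophenyl groups on the shared urea and core. Among the compounds shown here, the change that links compound 3 to compound 4, 3-chlorophenyl in place of ethyl, cannot be read, and the only readable step at this nitrogen is therefore the one between the two chlorophenyl groups. No measurement shown gives a reason for this result.

Going by these compounds, whether a small group such as ethyl on this nitrogen gives a number at all in this assay stays open, as the entry for compound 3 reads "not determined", and the same entry for compound 2 leaves the acetamide without a number too. Also open, on these data alone, is whether any other group at this place would give a number clearly apart from those of the two chlorophenyl compounds, such as a phenyl ring carrying a carboxylic acid or an amine, or a longer chain such as hexyl.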